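A few compounds are considered here, and "the series" means these few. Any claim that something is new, unique, unknown or untested is made for them only; others in the source may bear on it.

Working notes on the series. Compound 1 (`CC(=O)N(C)C(C)C#CCn1ccnc1`) gives > 100 mg/kg in a functional assay on the whole organism for antagonist activity, with Mus musculus as the target (a lower number here means that less compound is needed, a higher number that more compound is needed for the effect), a limit of the assay and not a number. Compound 2 (`CCOC(=O)N(C)CC#CCn1ccnc1`) gives > 100 mg/kg in this assay, again a limit and not a number. Among the measured compounds shown here, compound 2 thus stands at the limit of > 100 mg/kg in this assay, at which 2 of the 2 values shown sit, so it has no numerical value and no measured step links the two compounds.

Compound 3 (`CCOC(=O)N(C)C(C)C#CCn1ccnc1`) departs from compound 2 by a single change: methyl in place of hydrogen on a saturated chain carbon bound to an amide-type nitrogen and a triple-bonded carbon. No measurement in the series sizes this change. The expectation rests only on compound 2, whose reading of > 100 mg/kg is a limit. The expected change is a number no higher from compound 2 to compound 3 (the limit leaves the size open), an estimate that means no shift beyond the usual scatter in this assay, and another limit reading is quite possible. For compound 3 the estimated dose for half-maximal effect is 100 mg/kg, with an expected range from 30 mg/kg to 300 mg/kg.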

Compound 3, dose for half-maximal effect: > 100 mg/kg
Compound 3: a limit, no number; the forecaster's own chance of this, stated with the estimate: 60%; the middle value sits exactly at the limit.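

Compound 3 is a limit and not a number in this assay, as are compound 1 and compound 2, so neither the step from compound 2 to compound 3 nor the step from compound 1 to compound 3 can be read: the limit of > 100 mg/kg in this assay, at which 3 of the 3 values shown sit.

The compounds shown leave open whether methyl in place of hydrogen or ethoxy in place of methyl shifts the dose for half-maximal effect at all.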